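Swapping the benzyl thioether for an ethynyl thioether

The compounds below may be only part of what the source reports. "The series", "measured", "known", "first", "only" and "open" are said of these compounds alone.

Three compounds of one series have been measured in a functional assay on BGC-823 cells (Homo sapiens) for inhibition, read by MTT assay, with a stated time of 72 h; a higher number here means a weaker inhibitor, a lower number a stronger inhibitor:
Compound 1 `Cc1cc(N2CC[C@@H](C)[C@@H](N(C)c3ncnc4[nH]ccc34)C2)n2nc(SCc3ccccc3)nc2n1` gives 14400 nM.
Compound 2 `Cc1cc(N2CC[C@@H](C)[C@@H](N(C)c3ncnc4[nH]ccc34)C2)n2nc(SCc3ccc(Cl)cc3)nc2n1` gives 26300 nM.
Compound 3 `Cc1cc(N2CC[C@@H](C)[C@@H](N(C)c3ncnc4[nH]ccc34)C2)n2nc(SCc3ccc(F)c(Cl)c3)nc2n1` gives 98900 nM.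

Compound 2 sits second highest of the three numbers: the step of a 1.8-fold higher number from compound 1 to compound 2 (0.26 log units; within the scatter) lies within the scatter, while the step of a 3.8-fold higher number from compound 2 to compound 3 (0.58 log units; beyond the scatter) lies beyond it. Compound 4 `C#CSc1nc2nc(C)cc(N3CC[C@@H](C)[C@@H](N(C)c4ncnc5[nH]ccc45)C3)n2n1` is made from compound 2 by the change (ethynyl in place of 4-chlorobenzyl on a sulfur). Within the data shown here, none of the measured steps bears directly on it: the steps of a 1.8-fold higher number from compound 1 to compound 2 (0.26 log units; within the scatter) and a 6.9-fold higher number from compound 1 to compound 3 (0.84 log units; beyond the scatter) only vary the substituents on the benzyl ring that now leaves entirely. Among the measured compounds shown here, the measured range is narrow, and every step so far has raised the number, the largest being a 6.9-fold higher number from compound 1 to compound 3 (0.84 log units; beyond the scatter). For the measured compounds named here, with no comparable step to draw on, the expectation for compound 4 is a number near that of compound 2, giving an estimated step of a 1.1-fold lower number from compound 2 to compound 4 (0.02 log units; within the scatter). Compound 4 is therefore estimated at 25000 nM, with a range from 8000 nM to 80000 nM.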

Compound 4, half-maximal inhibitory concentration: 62100 nM
The estimate for compound 4 lay 2.5-fold (0.40 log units) below the measured number, and the stated range covers the measured number.
By their numbers in this assay, from the lowest: compounds 1 and 2 (each within the scatter of the next); then compounds 4 and 3 (each within the scatter of the next).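

Replacing the whole benzyl group on the sulfur with ethynyl gives a weaker inhibitor in this assay than the unsubstituted benzyl of compound 1 (a 4.3-fold higher number from compound 1 to compound 4 (0.63 log units; beyond the scatter)) and the 4-chlorobenzyl of compound 2 (a 2.4-fold higher number from compound 2 to compound 4 (0.37 log units; beyond the scatter)), so among these compounds both of those benzyl groups outperform the much smaller ethynyl. Yet the aromatic ring is not needed for a measurable value at this position, and ethynyl cannot be told apart from the 3-chloro-4-fluorobenzyl group of compound 3 (a 1.6-fold lower number from compound 3 to compound 4 (0.20 log units; within the scatter)). Nothing measured here explains these differences.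

From the compounds shown here alone, whether any group on the sulfur can give a lower number than the benzyl of compound 1 remains open. A longer chain, an amine or a carboxylic acid in this place could test how far the trend extends.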